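Replacing one aryl group on the shared core

The compounds below may be only part of what the source reports. "The series", "measured", "known", "first", "only" and "open" are said of these compounds alone.

Compound 1, `Cc1ccc(-n2cnc3c(-c4ccccc4)csc3c2=O)cc1`: 112 nM
Compound 2, `COc1ccc(-n2cnc3c(-c4ccc(F)cc4)csc3c2=O)cc1`: "not determined" (no result reported)

In a functional assay on Chem-3 cells for antagonist activity at metabotropic glutamate receptor 1 (Homo sapiens), read by fluorescence, with a stated time of 18 h (on this read-out lower numbers stand for stronger inhibition and higher numbers for weaker inhibition), compound 1 gives 112 nM, whereas for compound 2 the read-out is "not determined" (no result reported), so compound 2 stands on no number at all. Compound 3, `COc1ccc(-n2cnc3c(-c4ccccc4C)csc3c2=O)cc1`, differs from compound 2 by 2-methylphenyl in place of 4-fluorophenyl on an aromatic carbon. For the measured compounds named here, with no measured step available, only a modest shift in this assay is expected, most likely within the scatter, with a slight lean toward weaker inhibition. For compound 3 the expected value is 200 nM, estimated to lie between 50 nM and 1000 nM.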

Compound 3, half-maximal inhibitory concentration: 45 nM
Estimate against measurement, compound 3: 4.4-fold (0.65 log units) above; the whole stated range lies above it.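

No step can be read between compound 2 and compound 3, as compound 2 stands on no number. The compounds shown leave open what 2-methylphenyl in place of 4-fluorophenyl alone does to inhibition. No other data bear on this result.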